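A Ring Swap on the Chain Carbon of Compound 2

This account rests on a few compounds, and the source may have more. Where it says the series, first, only, none or still open, it means among the compounds named here.

Of the compounds shown here, three sharing one core have been measured in a physicochemical assay for solubility, measured as kinetic solubility, at pH 2; on this read-out higher numbers stand for higher solubility and lower numbers for lower solubility. Compound 1 `CC(C)C(c1nnc[nH]1)c1ccc(-c2ccc3cccc(F)c3c2)[nH]c1=O` gives 31800 nM. Compound 2 `CC(C)C(c1ccc(-c2ccc3cccc(F)c3c2)[nH]c1=O)N1CCCCC1=O` gives 23500 nM. Compound 3 `CCn1ncc2c(F)cc(-c3ccc(C(CC)(CC)c4nnc(C)[nH]4)c(=O)[nH]3)cc21` gives 33900 nM. Compound 2 has the lowest of the three numbers, but its gaps to compound 1 and to compound 3 both lie within the usual scatter of this assay, so the three compounds cannot be separated on solubility.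

Compound 4 `CC(C)C(c1noc(=O)[nH]1)c1ccc(-c2ccc3cccc(F)c3c2)[nH]c1=O` has not yet been measured. It differs from compound 2 in a single place: a group of 6 heavy atoms (2 carbon, 2 nitrogen, 2 oxygen; one five-membered aromatic ring with 3 hetero atoms) in place of a group of 7 heavy atoms (5 carbon, 1 nitrogen, 1 oxygen; one six-membered non-aromatic ring with 1 hetero atom), on a saturated chain carbon bound to an aromatic carbon and a saturated chain carbon. The entering group is a small five-membered aromatic ring rich in hetero atoms, which makes compound 4 resemble compound 1, with its 4H-1,2,4-triazol-3-yl group, more than it resembles compound 2.

Among the compounds with values here, only one measured step bears directly on this exchange: a 1.4-fold lower number from compound 1 to compound 2 (0.13 log units; within the scatter). That step replaced a small aromatic heterocycle on the same saturated chain carbon with the 2-oxopiperidin-1-yl group, and it did not move solubility beyond the scatter. The exchange from compound 2 to compound 4 runs the other way, so a step of similar small size is expected, a 1.2-fold higher number from compound 2 to compound 4 (0.08 log units; within the scatter), with no change beyond the scatter. Compound 4 is therefore estimated at 28000 nM, within a range from 14000 nM to 56000 nM.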

Compound 4, solubility: 23200 nM
The estimate for compound 4 lay 1.2-fold (0.08 log units) above the measured number, and the stated range covers the measured number.
By their numbers in this assay, from the lowest: compounds 4, 2, 1 and 3 (each within the scatter of the next).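

At the saturated chain carbon bound to an aromatic carbon and a saturated chain carbon, this assay now has a third group to compare, and replacing the 2-oxopiperidin-1-yl group with the five-membered aromatic ring of compound 4 gives a 1.0-fold lower number from compound 2 to compound 4 (0.01 log units; within the scatter), even though the entering group counts 1 hydrogen-bond donor and 3 hydrogen-bond acceptors against 0 donors and 1 acceptor for the leaving group. The exchange between two five-membered aromatic rings with 3 hetero atoms, one of them the 4H-1,2,4-triazol-3-yl group, gives a 1.4-fold lower number from compound 1 to compound 4 (0.14 log units; within the scatter), so neither new step separates the compounds on this read-out. Nothing shown here offers an explanation for this result.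

The compounds shown leave open whether a primary amine or a carboxylic acid on this same chain carbon would give a step beyond the scatter, as all three groups compared here carry no net charge. They also leave open whether the ring of compound 4 would read the same way on the core of compound 3, with its two ethyl chains on the corresponding carbon.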